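A few compounds are considered here, and "the series" means these few. Any claim that something is new, unique, unknown or untested is made for them only; others in the source may bear on it.

Three esters of a shared core have been tested in a functional assay on U-251 cells (Homo sapiens) for antiproliferative activity, read by sulforhodamine B assay, with a stated time of 72 h; on this read-out higher numbers stand for weaker inhibition and lower numbers for stronger inhibition. Compound 1 `COc1cc(/C=C/COC(C)=O)ccc1OC(C)=O` carries the smallest acyl groups and in this assay gives 9710 nM. Compound 3 `CCCC(=O)OC/C=C/c1ccc(OC(C)=O)c(OC)c1` carries a propylcarbonyl ester on the chain and an acetate on the phenol; in this assay compound 3 gives 33300 nM. Compound 2 `CCCC(=O)OC/C=C/c1ccc(OC(=O)CCC)c(OC)c1` carries propylcarbonyl groups on both oxygens, and for compound 2 this assay reports only a limit, > 50000 nM, rather than a number. Among the two numbers shown, compound 3 sits highest, a 3.4-fold higher number from compound 1 to compound 3 (0.54 log units; beyond the scatter). Against compound 2 the step is an at least 1.5-fold lower number from compound 2 to compound 3 (0.17 log units; that floor lies within the scatter), so the lengthening of the acyl chain has so far brought weaker inhibition or no clear change.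

Compound 4 `CC[C@H](C)C(=O)OC/C=C/c1ccc(OC(C)=O)c(OC)c1` differs from compound 3 in one place: methyl in place of hydrogen on a saturated chain carbon bound to a carbonyl carbon and a saturated chain carbon. This places a further carbon on the same chain that grew from compound 1 to compound 3, so the two measured steps, one a modest rise and one a limit, both point toward a similar or higher number in this assay. The expectation for compound 4 is therefore a step of a 1.4-fold higher number from compound 3 to compound 4 (0.13 log units; within the scatter), with a real chance that only a limit is reported. Compound 4 is estimated at 45000 nM, with a range from 15000 nM to 150000 nM.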

Compound 4, half-maximal inhibitory concentration: 28100 nM
Beside the measured number, compound 4's estimate is 1.6-fold (0.20 log units) above it; the measured number falls inside the stated range.
By their numbers in this assay, from the lowest: compound 1; then compounds 4 and 3 (each within the scatter of the next). At a limit, above all of these: compound 2.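

The new step shows that, on this ester chain, the change from propyl to sec-butyl does not separate the two compounds in this assay: a 1.2-fold lower number from compound 3 to compound 4 (0.07 log units; within the scatter). The earlier compounds shown here showed only that a propylcarbonyl ester in place of the acetate on the chain went with weaker inhibition, and compound 4 now shows that a branched chain at this place does the same, with a 2.9-fold higher number from compound 1 to compound 4 (0.46 log units; beyond the scatter). So, among these compounds, the clear difference lies between the small acetate of compound 1 and the larger acyl groups of compound 3 and compound 4, while the added methyl makes no measurable difference, and nothing given here explains the result.

The compounds shown leave open whether a much longer chain, a phenyl ring or an amine on this carbonyl carbon would stay in the same range or move clearly away from it. They also leave open whether the mirror-image sec-butyl ester would match compound 4, and whether a free hydroxyl in place of the acetate on the phenol would change the picture.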